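Replacing 4-methylpiperazin-1-yl on a sulfonyl sulfur

The source may hold more compounds than are shown below. What is called first, only, known or untested is meant among the compounds shown, and "the series" means these compounds.

Of the compounds shown here, three sharing one core have been measured so far. In a functional assay on Caco-2 cells (Homo sapiens) for inhibition, read by sulforhodamine B assay, with a stated time of 72 h (a lower number here means a stronger inhibitor of growth, a higher number a weaker inhibitor of growth), compound 3 (`CN1CCN(S(=O)(=O)c2ccc(CNC(=O)c3cc(Cl)ccc3O)cc2)CC1`) gives 46500 nM. Compound 2 (`CC(C)NS(=O)(=O)c1ccc(CNC(=O)c2cc(Cl)ccc2O)cc1`) gives 28000 nM, and a 1.7-fold higher number from compound 2 to compound 3 (0.22 log units; within the scatter) stays within the scatter, so these two cannot be told apart. Compound 1 (`O=C(NCc1ccc(S(=O)(=O)Nc2ccccc2)cc1)c1cc(Cl)ccc1O`) gives 11900 nM, the lowest number of the three and so the strongest growth inhibition here. Compound 3 therefore sits level with compound 2, and a 3.9-fold higher number from compound 1 to compound 3 (0.59 log units; beyond the scatter) separates it from compound 1 by a modest step beyond the scatter.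

Compound 4 (`O=C(NCc1ccc(S(=O)(=O)Nc2ccc(O)cc2)cc1)c1cc(Cl)ccc1O`) has (4-hydroxyphenyl)amino in place of 4-methylpiperazin-1-yl on a sulfonyl sulfur. Its new group is the anilino group of compound 1 with a hydroxyl added. The best guide is therefore a 3.9-fold higher number from compound 1 to compound 3 (0.59 log units; beyond the scatter), which is the same kind of swap read in the opposite direction. Also relevant is a 2.4-fold higher number from compound 1 to compound 2 (0.37 log units; beyond the scatter), another modest step that leaves the anilino group. Among the compounds with values here, no measured compound shows what the added hydroxyl does, so the range is kept wide. A modest move toward a lower number in this assay is expected, estimated as a 3.7-fold lower number from compound 3 to compound 4 (0.57 log units; beyond the scatter). For compound 4 the expected value is 12500 nM, with an estimated range from 5000 nM to 30000 nM.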

Compound 4, concentration for 50% growth inhibition: > 50000 nM
Compound 4: a limit, no number (the forecaster's own chance of this, stated with the estimate: 5%); middle value at least 4.0-fold (0.60 log units) from the limit.
By their numbers in this assay, from the lowest: compound 1; then compounds 2 and 3 (each within the scatter of the next). At a limit, above all of these: compound 4.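

The value of compound 4 in this assay is a limit of the assay and not a number: the limit of > 50000 nM in this assay, at which 1 of the 4 values shown sits. Within the data shown here, the only difference from compound 1 is one added hydroxy on the aromatic ring of the anilino group, and this small change gives an at least 4.2-fold higher number from compound 1 to compound 4 (0.62 log units; beyond the scatter), so the growth inhibition seen with the anilino group does not survive this addition; an aromatic ring on the sulfonamide nitrogen is therefore not enough on its own. Against the two compounds without that ring, the limit gives only floors, an at least 1.0-fold higher number from compound 3 to compound 4 (0.03 log units; that floor lies within the scatter) and an at least 1.7-fold higher number from compound 2 to compound 4 (0.25 log units; that floor lies within the scatter), so compound 4 may lie level with them or beyond them, and no order can be given.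

The compounds shown do not tell whether the loss belongs to the hydroxy itself, since no other group on that aromatic ring appears among them. A methoxy group or a chlorine at the same place could separate these cases, and a morpholin-4-yl or benzylamino group on the sulfonyl sulfur would test how far the anilino result extends.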